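A few compounds are considered here, and "the series" means these few. Any claim that something is new, unique, unknown or untested is made for them only; others in the source may bear on it.

Compound 1, `CN(CCC1CCNCC1)C(=O)c1ccc2c(c1)CC(CC(=O)O)C(=O)N(C1CCCCC1)C2`, gives 49 nM in a functional assay (plasma) for inhibition, with Homo sapiens as the target; on this read-out higher numbers stand for weaker inhibition and lower numbers for stronger inhibition.
Compound 2, `CN(CCC1CCNCC1)C(=O)c1ccc2c(c1)CC(CC(=O)O)C(=O)N(Cc1ccccc1)C2`, gives 36 nM.
Compound 3, `CN(CCC1CCNCC1)C(=O)c1ccc2c(c1)CC(CC(=O)O)C(=O)N(CCC1CCCCC1)C2`, gives 27 nM.

Among these three numbers compound 2 stands second highest; its nearest neighbour is compound 3, with a 1.3-fold lower number from compound 2 to compound 3 (0.12 log units; within the scatter), and the step of a 1.4-fold lower number from compound 1 to compound 2 (0.13 log units; within the scatter) is likewise within the scatter, so all three lie together. Compound 4, `CC(C)CCN1Cc2ccc(C(=O)N(C)CCC3CCNCC3)cc2CC(CC(=O)O)C1=O`, differs from compound 2 by isobutyl in place of phenyl on a saturated chain carbon bound to an amide-type nitrogen in a ring. The step that bears on this most directly is a 1.3-fold lower number from compound 2 to compound 3 (0.12 log units; within the scatter), which replaces the same phenyl on the same carbon; the step of a 1.8-fold lower number from compound 1 to compound 3 (0.26 log units; within the scatter) at the same nitrogen also stays within the scatter. Compound 4 is therefore expected to show a 1.1-fold higher number from compound 2 to compound 4 (0.02 log units; within the scatter), nothing beyond the scatter. The estimate for compound 4 in this assay is 38 nM, within 18 nM to 80 nM.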

Compound 4, half-maximal inhibitory concentration: 32 nM
Compound 4: the middle estimate sits 1.2-fold (0.07 log units) above what was measured, and the stated range covers the measured number.
By their numbers in this assay, from the lowest: compounds 3, 4, 2 and 1 (each within the scatter of the next).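

Replacing phenyl with isobutyl at this place leaves the number where it was (a 1.1-fold lower number from compound 2 to compound 4 (0.05 log units; within the scatter)) in this assay, and the steps to the other two compounds also stay within the scatter (a 1.2-fold higher number from compound 3 to compound 4 (0.07 log units; within the scatter); a 1.5-fold lower number from compound 1 to compound 4 (0.19 log units; within the scatter)). Among these four compounds, then, a ring in this substituent is not required, since the open branched isopentyl on the amide-type nitrogen sits with the cyclohexyl, benzyl and 2-cyclohexylethyl groups. No evidence accompanies these compounds to account for this flat response.

On these data alone, whether a chain ending in an amine, a hydroxyl or a carboxylic acid would fit the same pattern remains open. So does the effect of a group as short as methyl on this nitrogen.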